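Aryl swap on the ring nitrogen: compounds 1 to 4

This account rests on a few compounds, and the source may have more. Where it says the series, first, only, none or still open, it means among the compounds named here.

Measured so far, in a functional assay on MCF7 cells (Homo sapiens) for cytotoxicity, read by MTT assay, with a stated time of 72 h; on this read-out higher numbers stand for weaker inhibition and lower numbers for stronger inhibition:
- compound 1 `Cc1cc(=O)n(-c2cccc(F)c2)nc1C(=O)Nc1ccc(Oc2ncnc3[nH]ccc23)c(F)c1`: compound 1 gives 32000 nM
- compound 2 `Cc1cc(=O)n(-c2ccc(Br)cc2F)nc1C(=O)Nc1ccc(Oc2ncnc3[nH]ccc23)c(F)c1`: compound 2 gives 26600 nM
- compound 3 `Cc1cc(=O)n(-c2ccc(Br)cc2F)nc1C(=O)Nc1ccc(Oc2ncnc3c2ccn3C)cc1`: compound 3 gives 27700 nM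

Compound 2 and compound 1 differ in one place, (3-fluorophenyl in place of 4-bromo-2-fluorophenyl on an aromatic nitrogen). The step of a 1.2-fold higher number from compound 2 to compound 1 (0.08 log units; within the scatter) is within the scatter. Compound 3 and compound 2 differ in more than one place; the difference between the two cores is not broken down here, and their values sit within the scatter of each other.

Compound 4 `Cc1cc(=O)n(-c2cccc(F)c2)nc1C(=O)Nc1ccc(Oc2ncnc3c2ccn3C)cc1` differs from compound 3 by 3-fluorophenyl in place of 4-bromo-2-fluorophenyl on an aromatic nitrogen; the surroundings read the same, so this is the same change. The expectation rests on the measured step of a 1.2-fold higher number from compound 2 to compound 1 (0.08 log units; within the scatter). The expected step is a 1.1-fold higher number from compound 3 to compound 4 (0.05 log units; within the scatter). Compound 4 is estimated at 31000 nM, with a likely range from 15000 nM to 65000 nM.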

Compound 4, half-maximal inhibitory concentration: 30800 nM
Compound 4: the middle estimate sits 1.0-fold (0.00 log units) above what was measured, and the stated range covers the measured number.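

In this assay, 3-fluorophenyl in place of 4-bromo-2-fluorophenyl on the aromatic nitrogen gives a 1.1-fold higher number from compound 3 to compound 4 (0.05 log units; within the scatter), and the two cores agree on this change: the same change on two cores in this assay, a 1.2-fold higher number (0.08 log units; within the scatter) from compound 2 to compound 1 and a 1.1-fold higher number (0.05 log units; within the scatter) from compound 3 to compound 4, 1.1-fold (0.03 log units) apart, within the scatter of two such steps

Among the compounds shown here, both steps lie within the scatter, so the pairs show only that this swap leaves no readable difference on either core. They do not show that a step of real size would carry from one core to the other, since neither pair offers such a step to compare.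

Open, from the compounds shown here alone, is whether another kind of group on that aromatic nitrogen, such as a phenyl ring carrying an amine or a carboxylic acid, would shift the number on either core. Open too, going by these compounds, is whether any such shift would hold across both cores.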